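Sulfonamide aryl variation on the shared core

The compounds below may be only part of what the source reports. "The series", "measured", "known", "first", "only" and "open" are said of these compounds alone.

Measured compounds:
- compound 1, `O=S(=O)(Nc1ccc(-c2nc3ccccc3o2)cc1)c1ccccc1O` — > 100000 nM
- compound 2, `C=Cc1ccc(S(=O)(=O)Nc2ccc(-c3nc4ccccc4o3)cc2)cc1` — > 100000 nM
- compound 3, `COc1ccc(S(=O)(=O)Nc2ccc(-c3nc4ccccc4o3)cc2)cc1` — > 100000 nM

In an assay on cells for inhibition of HSP60/HSP10 (Homo sapiens), with a stated time of 60 min (on this read-out higher numbers stand for weaker inhibition and lower numbers for stronger inhibition), compound 1 gives only a limit of the assay, > 100000 nM, not a number. Compound 2 likewise returns only a limit in this assay, > 100000 nM. Compound 3 as well gives only a limit, > 100000 nM. All three values sit at the limit of > 100000 nM in this assay, at which 3 of the 3 values shown sit, so the steps a step that the two limits leave unreadable from compound 1 to compound 2, a step that the two limits leave unreadable from compound 1 to compound 3 and a step that the two limits leave unreadable from compound 2 to compound 3 cannot be read in size or direction.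

Compound 4, `O=S(=O)(Nc1ccc(-c2nc3ccccc3o2)cc1)c1ccccc1C(F)(F)F`, differs from compound 1 by trifluoromethyl in place of hydroxy on an aromatic carbon. The measured steps that bear on it, those from compound 1 to compound 2 and from compound 1 to compound 3, are unreadable, so they give no size to expect for this assay in either direction. With every measured member of the series at the limit, compound 4 is expected to come out the same way, most likely again as a limit rather than a number. The step that the limit leaves unreadable from compound 1 to compound 4 is therefore only a nominal estimate, not a readable change. For compound 4 the expected value in this assay is 150000 nM, with a range from 40000 nM to 600000 nM.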

Compound 4, half-maximal inhibitory concentration: 74000 nM
Compound 4: middle estimate off by 2.0-fold (0.31 log units), on the high side; the measured number falls inside the stated range.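

In this assay, among these compounds, compound 4 gives 74000 nM, the first number rather than a limit, and it comes from a change on an aromatic carbon ortho to a large group. Compound 1 gives > 100000 nM, which is a limit. Trifluoromethyl in place of hydroxy therefore gives an at least 1.3-fold lower number from compound 1 to compound 4 (0.13 log units; that floor lies within the scatter), so the step has a direction only as far as that floor allows, and its full size stays unknown: the limit of > 100000 nM in this assay, at which 3 of the 4 values shown sit.

The compounds shown leave open whether a number at this position is particular to trifluoromethyl or would also appear with another group there, such as an amine, a carboxylic acid or a simple methyl. Going by these compounds, the true size of the step also stays open, with no number for compound 1.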